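This account rests on a few compounds, and the source may have more. Where it says the series, first, only, none or still open, it means among the compounds named here.

Compound 1 `O=C(COc1ccc2c(=O)cc(-c3ccccc3)oc2c1)Nc1ccc2ccccc2c1` and compound 2 `O=C(COc1ccc2c(=O)c(-c3ccccc3)coc2c1)Nc1ccc2ccccc2c1` are built from the same atoms joined differently; the difference between the two cores is not broken down here. In a functional assay on NCI-H661 cells (Homo sapiens) for antiproliferative activity, read by MTT assay, with a stated time of 72 h (a lower number here means a stronger inhibitor of growth, a higher number a weaker inhibitor of growth), compound 1 gives only a limit, > 10000 nM. Compound 2 likewise gives only a limit in this assay, > 10000 nM. Compound 3 `O=C(COc1ccc2c(=O)cc(-c3ccccc3)oc2c1)Nc1ccccc1` differs from compound 1 by phenyl in place of naphthalen-2-yl on an amide-type nitrogen, and in this assay compound 3 also gives only a limit, > 10000 nM. The step that the two limits leave unreadable from compound 1 to compound 3 cannot be read because of the limit of > 10000 nM in this assay, at which 3 of the 3 values shown sit. Compound 4 `O=C(COc1ccc2c(=O)c(-c3ccccc3)coc2c1)Nc1ccccc1` carries the same change relative to compound 2: phenyl in place of naphthalen-2-yl on an amide-type nitrogen. Since that change gave no readable step and compound 2 itself shows only a limit, compound 4 is expected to remain at the limit as well. For compound 4 the expected step is a step that the limit leaves unreadable from compound 2 to compound 4. Compound 4 is estimated at 15000 nM, within 5000 nM to 50000 nM.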

Compound 4, concentration for 50% growth inhibition: > 10000 nM
Compound 4 was reported as a limit; the forecaster's own chance of this, stated with the estimate: 80%; the middle value is on the limit's open side.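

No step can be read from compound 2 to compound 4, because both values are limits: the limit of > 10000 nM in this assay, at which 4 of the 4 values shown sit.

The compounds shown leave open whether swapping naphthalen-2-yl for phenyl, or the difference between the two cores, changes growth inhibition at all.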